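The compounds below may be only part of what the source reports. "The series", "measured", "known", "first", "only" and "open" are said of these compounds alone.

Working notes on the series, read in a functional assay on MIA cells (Homo sapiens) for cytotoxicity, read by MTT assay, with a stated time of 72 h; on this read-out lower numbers stand for stronger inhibition of growth and higher numbers for weaker inhibition of growth. Compound 1 `N#C/C(=C/c1ccc2ccccc2c1)C(=O)c1ccc[nH]1` gives < 10000 nM, which is a limit of the assay and not a number. Compound 3 `N#C/C(=C/c1ccc(Cl)c(Cl)c1)C(=O)c1ccc[nH]1` gives < 10000 nM, also a limit and not a number. Going by the values given here, compound 2 `N#C/C(=C/c1ccc(Cl)cc1)C(=O)c1ccc[nH]1` gives 59000 nM, the only actual number so far.

Compound 4 `N#C/C(=C/c1ccc(O)cc1)C(=O)c1ccc[nH]1` is still to be measured. It carries hydroxy in place of chloro on an aromatic carbon, para to a large group: hydroxy in place of chloro on an aromatic carbon.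

Among the compounds with values here, the only measured step on this ring is an at least 5.9-fold lower number from compound 2 to compound 3 (0.77 log units; beyond the scatter), with chloro in place of hydrogen on an aromatic carbon. It bears on the change only indirectly, since it adds a chloro at another place and involves no hydroxy. It shows that a single substituent on this ring can move the read-out, but it gives no size or direction for this exchange. A large gain would end at the limit of < 10000 nM in this assay, at which 2 of the 3 values shown sit, and yield no number.

Within the data shown here, with no measured hydroxy example, no shift beyond the scatter is expected. The expected step is a 1.3-fold lower number from compound 2 to compound 4 (0.12 log units; within the scatter). The estimate for compound 4 is 45000 nM, with an expected range of 12000 nM to 130000 nM.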

Compound 4, concentration for 50% growth inhibition: 11000 nM
Estimate against measurement, compound 4: 4.1-fold (0.61 log units) above, and the stated range ends above it.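

In this assay, the exchange of chloro for hydroxy on an aromatic carbon, para to a large group, is not neutral: it gives a 5.4-fold lower number from compound 2 to compound 4 (0.73 log units; beyond the scatter). Going by these compounds alone, the earlier step, an at least 5.9-fold lower number from compound 2 to compound 3 (0.77 log units; beyond the scatter), added a chloro at another place, whereas this one replaces the chloro itself, so it is the first reading of a change at this position. Hydroxy brings a hydrogen-bond donor and a hydrogen-bond acceptor where chloro brings neither, and the step has a definite size, since compound 4 returns a number and does not join the values at the limit of the assay: the limit of < 10000 nM in this assay, at which 2 of the 4 values shown sit.

Going by these compounds, with one exchange at this position, the series cannot separate what hydroxy adds from what the loss of chloro removes, and how plain hydrogen, methoxy, an amine or a carboxylic acid would read at the same carbon stays open. Also open, on these data alone, is whether hydroxy keeps the same effect when a second group sits on the same ring, and whether it carries over to other cells.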